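The source may report more compounds than this note shows. Statements on the series, on what has been measured and on what is new or still open speak of the compounds shown alone.

Measured compounds:
Compound 1, `Fc1ccc(C2CCN(c3ccn4c(CC5CC5)nnc4c3Cl)CC2)c(F)c1`, gives 61.7 nM in a functional assay on CHO cells for agonist activity at metabotropic glutamate receptor 2 (Homo sapiens), read by scintillation counting and GTPgammaS binding, with a stated time of 30 min; on this read-out lower numbers stand for an effect already at smaller amounts and higher numbers for an effect only at larger amounts of compound.
Compound 2, `COc1c(F)cccc1C1CCN(c2ccn3c(CC4CC4)nnc3c2Cl)CC1`, gives 37 nM in this assay.

Compound 1 and compound 2 share the same core and differ only in the aromatic group on a saturated ring carbon. Among the measured compounds shown here, the one measured step, a 1.7-fold lower number from compound 1 to compound 2 (0.22 log units; within the scatter), shows that these two numbers cannot be told apart, so compound 2 stands together with compound 1 rather than apart from it.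

Compound 3, `COc1cc(F)cc(F)c1C1CCN(c2ccn3c(CC4CC4)nnc3c2Cl)CC1`, is not yet measured in this assay. It differs from compound 2 in one place: 2,4-difluoro-6-methoxyphenyl in place of 3-fluoro-2-methoxyphenyl on a saturated ring carbon. For the measured compounds named here, the only step that bears on this change is the one from compound 1 to compound 2, in which swapping one fluorinated aromatic group for another that also carries a methoxy group stayed within the scatter. A second swap of the same kind, again keeping a methoxy group and fluorine on the aromatic ring, is therefore expected to give no step beyond the scatter in this assay, in either direction.

Compound 3 is accordingly estimated at 45 nM, with a range from 15 nM to 150 nM. The expected step, a 1.2-fold higher number from compound 2 to compound 3 (0.09 log units; within the scatter), is one that lies within the scatter.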

Compound 3, half-maximal effective concentration: 6.9 nM
Compound 3: middle estimate off by 6.5-fold (0.81 log units), on the high side; measured number outside the range, below it.
By their numbers in this assay, from the lowest: compound 3; then compounds 2 and 1 (each within the scatter of the next).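

The aromatic group on the saturated ring carbon turns out to be less interchangeable than the first swap suggested: in this assay, 2,4-difluoro-6-methoxyphenyl in place of 3-fluoro-2-methoxyphenyl gives a step beyond the scatter (a 5.4-fold lower number from compound 2 to compound 3 (0.73 log units; beyond the scatter)). The cleanest reading comes from the pair that differs by a single added group, where methoxy in place of hydrogen on an aromatic carbon turns 2,4-difluorophenyl into 2,4-difluoro-6-methoxyphenyl and also moves the number beyond the scatter (an 8.9-fold lower number from compound 1 to compound 3 (0.95 log units; beyond the scatter)), so on this ring one methoxy group is enough to make a clear difference in this series. Nothing available here accounts for either step.

Compound 2 and compound 3 differ both in how many fluorines the aromatic ring carries and in where its groups sit, so these compounds cannot show which of the two matters. As far as these compounds go, it also remains open whether the lower number is specific to methoxy or would also appear with an ethoxy group, a hydroxyl group or a dimethylamino group in its place on the same aromatic ring.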